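Acylguanidine series: thiophenylethyl in place of hexyl

The source may hold more compounds than are shown below. What is called first, only, known or untested is meant among the compounds shown, and "the series" means these compounds.

Compound 3 `CCCCCCNC(=O)/N=C(\N)NCCCc1sc(N)nc1C` carries a hexyl group on the amide-type nitrogen. In an assay on membranes from Sf9 cells for displacement of a labelled ligand from histamine H2 receptor (Homo sapiens), read by scintillation counting, with a stated time of 60 min (a lower number here means a stronger inhibitor, a higher number a weaker inhibitor), compound 3 gives 28.8 nM, level at the digits printed with compound 2 `Cc1nc(N)sc1CCCN/C(N)=N/C(=O)NC(C)c1ccccc1F`, which gives 28.8 nM; compound 1 `COc1ccc(C(C)NC(=O)/N=C(\N)NCCCc2sc(N)nc2C)cc1` gives 37.2 nM, and the step of a 1.3-fold lower number from compound 1 to compound 2 (0.11 log units; within the scatter) is within the scatter. The three numbers therefore sit together, none of them separated from the others beyond the scatter.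

Compound 4 `Cc1nc(N)sc1CCCN/C(N)=N/C(=O)NC(C)c1cccs1` differs from compound 3 by 1-(thiophen-2-yl)ethyl in place of hexyl on an amide-type nitrogen. Going by the values given here, no measured step exchanges a chain for a ring-bearing group on this nitrogen. Among the compounds with values here, the only measured step, a 1.3-fold lower number from compound 1 to compound 2 (0.11 log units; within the scatter), swaps 2-fluorophenyl for 4-methoxyphenyl and stays within the scatter, and compound 3 with hexyl matches compound 2 with its ring at the digits printed. The series thus shows no movement across these variations, so no step beyond the scatter is expected in this assay. Compound 4 is expected to give about 30 nM, with a range of 15 nM to 60 nM, the step of a 1.0-fold higher number from compound 3 to compound 4 (0.02 log units; within the scatter) being expected to lie within the scatter.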

Compound 4, inhibition constant: 63.1 nM
For compound 4 the middle estimate is 2.1-fold (0.32 log units) below the measured one; measured number above the stated range.
By their numbers in this assay, from the lowest: compounds 2, 3, 1 and 4 (each within the scatter of the next, the first and the last beyond it).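

In this assay the amide-type nitrogen shows its first step beyond the scatter, with 1-(thiophen-2-yl)ethyl in place of hexyl giving a 2.2-fold higher number from compound 3 to compound 4 (0.34 log units; beyond the scatter) and only a modest change in size. On the saturated chain carbon, thiophen-2-yl in place of 2-fluorophenyl gives a 2.2-fold higher number from compound 2 to compound 4 (0.34 log units; beyond the scatter) while thiophen-2-yl in place of 4-methoxyphenyl gives a 1.7-fold higher number from compound 1 to compound 4 (0.23 log units; within the scatter) so that the ring swap separates compound 4 from compound 2 but not from compound 1. Nothing available bears on the reason for these differences.

Open, as far as these compounds go, is whether an unbranched 2-(thiophen-2-yl)ethyl group, a benzyl group or a longer chain such as octyl on this nitrogen would read with compound 3 or with compound 4. Also open, from the compounds shown here alone, is whether a furan-2-yl or pyridin-2-yl ring on the saturated chain carbon would read with compound 2 or with compound 4.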